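Swapping the 2-hydroxy-2-methylbutyl Group of Compound 2 for Oxan-2-yl

The compounds below may be only part of what the source reports. "The series", "measured", "known", "first", "only" and "open" are said of these compounds alone.

In a functional assay on DU-145 cells (Homo sapiens) for cytotoxicity, read by MTT assay (a higher number here means a weaker inhibitor, a lower number a stronger inhibitor), compound 1 (`CC(=O)OCCO[C@H](CC=C(C)C)C1=CC(=O)c2c(O)ccc(O)c2C1=O`) gives 15500 nM, and compound 2 (`CC[C@@](C)(O)CC(=O)O[C@H](CC=C(C)C)C1=CC(=O)c2c(O)ccc(O)c2C1=O`) gives 12700 nM. Among the measured compounds shown here, these are the only two numbers available. For the measured compounds named here, the one measured step is a 1.2-fold lower number from compound 1 to compound 2 (0.09 log units; within the scatter). Compound 2 therefore stands level with compound 1, and the two cannot be ranked.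

Compound 3 (`CC(C)=CC[C@@H](OC(=O)C1CCCCO1)C1=CC(=O)c2c(O)ccc(O)c2C1=O`) keeps the shared core of compound 2 and alters only the group on the carbonyl carbon: oxan-2-yl in place of 2-hydroxy-2-methylbutyl on a carbonyl carbon. In words, oxan-2-yl takes the place of 2-hydroxy-2-methylbutyl on a carbonyl carbon.

Going by the values given here, the single measured step bears on this change only indirectly, since it also exchanged the side chain on the same oxygen and stayed small: a 1.2-fold lower number from compound 1 to compound 2 (0.09 log units; within the scatter). Neither measured compound carries the ring that enters here, so the evidence is thin and the range must stay wide. No shift beyond the scatter is expected in either direction in this assay.

The expected step is a 1.0-fold higher number from compound 2 to compound 3 (0.01 log units; within the scatter). For compound 3 the estimated value is 13000 nM, with an expected range from 6000 nM to 28000 nM.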

Compound 3, half-maximal inhibitory concentration: 24700 nM
For compound 3 the middle estimate is 1.9-fold (0.28 log units) below the measured one; measured number inside the range.
By their numbers in this assay, from the lowest: compounds 2, 1 and 3 (each within the scatter of the next).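

In this assay, the first ring at this position, oxan-2-yl on a carbonyl carbon in place of the open 2-hydroxy-2-methylbutyl, gives a 1.9-fold higher number from compound 2 to compound 3 (0.29 log units; within the scatter) even though the entering group has no hydrogen-bond donor and the leaving group has one. The wider change, (oxan-2-yl)carbonyl in place of 2-acetoxyethyl on an oxygen on a saturated carbon, gives a 1.6-fold higher number from compound 1 to compound 3 (0.20 log units; within the scatter) in the same assay, so all three side chains shown on this oxygen, open or ring-bearing, stay within the scatter of one another. No measurement of any property of these compounds is available to explain these small steps.

What the three compounds leave open is whether any group on this carbonyl carbon can move the number beyond the scatter, since a cyclohexyl ring without the ring oxygen, a basic amine such as a piperidin-4-yl group, a carboxylic acid or a much longer alkyl chain does not appear among them. They also leave open whether the defined stereocentre of the 2-hydroxy-2-methylbutyl group matters, as its opposite form is not among the compounds shown here.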